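From (ethylcarbamoyl)amino to (ethoxycarbonyl)amino

The compounds below may be only part of what the source reports. "The series", "measured", "known", "first", "only" and "open" are said of these compounds alone.

Compound 1 `CN1Cc2c(N)cccc2C(c2ccc(Cl)cc2)C1`: 1.5 mg/kg in a functional assay on the whole organism for inhibition of sodium-dependent dopamine transporter (Mus musculus); a lower number here means that less compound is needed, a higher number that more compound is needed for the effect
Compound 2 `CCNC(=O)Nc1cccc2c1CN(C)CC2c1ccccc1`: > 80 mg/kg, a limit of the assay rather than a number
Compound 3 `CCCCNC(=O)Nc1cccc2c1CN(C)CC2c1ccc(C)cc1`: > 100 mg/kg, again a limit of the assay

Compound 2 stands at the edge of what this assay can report: its result is only a limit (the limit of > 80 mg/kg in this assay, at which 1 of the 3 values shown sits), so no number for it exists. Compound 4 `CCOC(=O)Nc1cccc2c1CN(C)CC2c1ccccc1` differs from compound 2 by ethoxy in place of ethylamino on a carbonyl carbon. Among the measured compounds shown here, no measured pair shows what this change does in this assay, so its size is unknown. With compound 2 giving only a limit, a reading near compound 2 and no movement beyond the usual scatter is expected: a step that the limit leaves unreadable from compound 2 to compound 4. For compound 4 the estimate is 100 mg/kg, within 30 mg/kg to 300 mg/kg, quite possibly again only a limit.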

Compound 4, dose for half-maximal effect: 2.5 mg/kg
Compound 4: middle estimate off by 40-fold (1.60 log units), on the high side, and the stated range ends above it.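

In this assay, the group on this carbonyl carbon proves decisive: ethoxy in place of ethylamino gives an at least 32-fold lower number from compound 2 to compound 4 (1.50 log units; beyond the scatter). The true size of this step may be larger, as the result for compound 2 is only a limit of the assay: the limit of > 80 mg/kg in this assay, at which 1 of the 4 values shown sits.

The change removes the hydrogen-bond donor of ethylamino and brings in an oxygen, and the compounds shown cannot separate these two differences. Also open, as far as these compounds go, is how much room this position allows, which a longer butoxy, or a methyl on the same carbonyl carbon, would test.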